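The source may report more compounds than this note shows. Statements on the series, on what has been measured and on what is new or still open speak of the compounds shown alone.

Measured so far:
compound 1 `Cc1ccncc1-c1cc(F)cc(-n2nnc(-c3ccccn3)n2)c1` — 1.8 nM
compound 2 `N#Cc1cccc(-n2nnc(-c3cc[nH]n3)n2)c1` — > 2000 nM
compound 3 `N#Cc1cc(F)cc(-n2nnc(-c3ncc[nH]3)n2)c1` — 9.3 nM

In an assay for binding affinity to metabotropic glutamate receptor 5 (Rattus norvegicus) (a lower number here means a stronger inhibitor, a higher number a weaker inhibitor), compound 2 gives only a limit, > 2000 nM; this is the limit line (the limit of > 2000 nM in this assay, at which 1 of the 3 values shown sits), so its true value is not known. Compound 1 gives 1.8 nM and compound 3 gives 9.3 nM in this assay.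

Compound 4 `N#Cc1cccc(-n2nnc(-c3c[nH]cn3)n2)c1` is not yet measured. It differs from compound 2 by one change: 1H-imidazol-4-yl in place of 1H-pyrazol-3-yl on an aromatic carbon. The two have the same atoms, joined differently. Going by the values given here, no step between measured compounds covers this change, so the expected size rests on the limit of compound 2 alone. A gain is expected, of size an at least 1.6-fold lower number from compound 2 to compound 4 (0.22 log units; that floor lies within the scatter), though a result at the limit remains possible. Compound 4 is estimated at 1200 nM, within 150 nM to 6000 nM.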

Compound 4, inhibition constant: > 2000 nM
Compound 4: only a limit was reported (the forecaster's own chance of this, stated with the estimate: 40%); at least 1.6-fold (0.22 log units) between middle value and limit.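

No step can be read from compound 2 to compound 4, because each gives only a limit: the limit of > 2000 nM in this assay, at which 2 of the 4 values shown sit.

Still open, going by these compounds, is whether 1H-imidazol-4-yl in place of 1H-pyrazol-3-yl changes the result at all in this assay.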